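Aryl variation at the biaryl position: cytotoxicity notes

The source may report more compounds than this note shows. Statements on the series, on what has been measured and on what is new or still open speak of the compounds shown alone.

Measured so far:
- compound 1, `Cc1cc(-c2cccc(F)c2)cc(C)c1Nc1ccnc(Nc2ccc(C#N)cc2)n1`: 4120 nM
- compound 2, `Cc1cc(-c2ccc(C(F)(F)F)cc2)cc(C)c1Nc1ccnc(Nc2ccc(C#N)cc2)n1`: 4160 nM
- compound 3, `Cc1cc(-c2cc(Cl)cc(Cl)c2)cc(C)c1Nc1ccnc(Nc2ccc(C#N)cc2)n1`: 4290 nM

All three values come from an ADME assay on MT4 cells (Homo sapiens) for cytotoxicity, read by MTT assay, with a stated time of 4 days; a lower number here means that less compound is tolerated, a higher number that more compound is tolerated. Compound 3 sits level with the other two: the steps of a 1.0-fold higher number from compound 1 to compound 3 (0.02 log units; within the scatter) and a 1.0-fold higher number from compound 2 to compound 3 (0.01 log units; within the scatter) are both within the scatter, as is a 1.0-fold higher number from compound 1 to compound 2 (0.00 log units; within the scatter). Compound 4, `Cc1cc(-c2ccccc2Cl)cc(C)c1Nc1ccnc(Nc2ccc(C#N)cc2)n1`, differs from compound 3 by 2-chlorophenyl in place of 3,5-dichlorophenyl on an aromatic carbon. The three measured steps at this position all left this assay unchanged, so no step beyond the scatter is expected for compound 4 either; the step of a 1.0-fold lower number from compound 3 to compound 4 (0.01 log units; within the scatter) is an estimate of no real movement. The expected value for compound 4 is 4200 nM, with a range from 2000 nM to 8500 nM.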

Compound 4, half-maximal cytotoxic concentration: 3990 nM
The estimate for compound 4 lay 1.1-fold (0.02 log units) above the measured number; measured number inside the range.
By their numbers in this assay, from the lowest: compounds 4, 1, 2 and 3 (each within the scatter of the next).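

In this assay, 2-chlorophenyl reads level with all three earlier aryl groups, with a 1.1-fold lower number from compound 3 to compound 4 (0.03 log units; within the scatter) and a 1.0-fold lower number from compound 2 to compound 4 (0.02 log units; within the scatter) and a 1.0-fold lower number from compound 1 to compound 4 (0.01 log units; within the scatter). Across these four compounds, the choice among the aryl groups shown therefore has no readable effect on this number. No evidence is available that bears on this result.

The aryl groups shown carry only fluorine, chlorine or trifluoromethyl. As far as these compounds go, whether an amine or a carboxylic acid on this ring, or a saturated piperidine in place of it, would move the number beyond the scatter stays open.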